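The source may hold more compounds than are shown below. What is called first, only, known or untested is meant among the compounds shown, and "the series" means these compounds.

Compound 1 `CCN(C)C(=O)N1CCN(C(=S)SCc2cn(Cc3ccccc3F)nn2)CC1`: 15600 nM
Compound 2 `O=C(NC1CCCCC1)N1CCN(C(=S)SCc2cn(Cc3ccccc3F)nn2)CC1`: 84900 nM
Compound 3 `CCN(C)C(=O)N1CCN(C(=S)SCc2cn(Cc3ccc(F)cc3)nn2)CC1`: 14300 nM

All three measured compounds were tested in a functional assay on EC9706 cells (Homo sapiens) for cytotoxicity, read by MTT assay, with a stated time of 72 h; a lower number here means a stronger inhibitor, a higher number a weaker inhibitor. Compound 1 and compound 2 share the same core and differ in one place: cyclohexylamino in place of ethyl(methyl)amino on a carbonyl carbon. That change gave a 5.4-fold higher number from compound 1 to compound 2 (0.74 log units; beyond the scatter). Compound 3 differs from compound 1 only in the core: 4-fluorophenyl in place of 2-fluorophenyl on a saturated chain carbon bound to an aromatic nitrogen. Here the numbers stayed close, with a 1.1-fold lower number from compound 1 to compound 3 (0.04 log units; within the scatter), so compound 1 and compound 3 cannot be told apart in this assay.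

The unmeasured compound 4 `O=C(NC1CCCCC1)N1CCN(C(=S)SCc2cn(Cc3ccc(F)cc3)nn2)CC1` stands to compound 3 exactly as compound 2 stands to compound 1: cyclohexylamino in place of ethyl(methyl)amino on a carbonyl carbon. The surroundings of the place are the same in both pairs, so this is the same change, now carried on the core of compound 3. Among the compounds with values here, since the core change from compound 1 to compound 3 left the number essentially unchanged, the one earlier example of this change is the only guide, and it points to a weaker inhibitor.

Compound 4 is expected to give 75000 nM in this assay. For compound 4 the lower end of the estimate is 35000 nM. For compound 4 the upper end of the estimate is 160000 nM. Within the data shown here, the expected step is a 5.2-fold higher number from compound 3 to compound 4 (0.72 log units; beyond the scatter), resting on the single prior step a 5.4-fold higher number from compound 1 to compound 2 (0.74 log units; beyond the scatter), and it is therefore uncertain.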

Compound 4, half-maximal inhibitory concentration: > 128000 nM
Compound 4 gave a limit, no number (the forecaster's own chance of this, stated with the estimate: 8%); middle value at least 1.7-fold (0.23 log units) away from the limit.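

In this assay, compound 4 gave > 128000 nM, which is a limit of the assay and not a number. Cyclohexylamino in place of ethyl(methyl)amino gave an at least 8.9-fold higher number from compound 3 to compound 4 (0.95 log units; beyond the scatter), so the change pointed the same way on the core of compound 3 as on the core of compound 1, but this does not show that its size is the same on both cores: the same change on two cores in this assay, a 5.4-fold higher number (0.74 log units; beyond the scatter) from compound 1 to compound 2 and an at least 8.9-fold higher number (0.95 log units; beyond the scatter) from compound 3 to compound 4; the limit leaves it open whether they differ. On the cyclohexylamino pair, the exchange of 2-fluorophenyl for 4-fluorophenyl gave an at least 1.5-fold higher number from compound 2 to compound 4 (0.17 log units; that floor lies within the scatter), a floor that neither shows that the exchange matters with cyclohexylamino present nor rules it out: the same change on two cores in this assay, a 1.1-fold lower number (0.04 log units; within the scatter) from compound 1 to compound 3 and an at least 1.5-fold higher number (0.17 log units; that floor lies within the scatter) from compound 2 to compound 4; the limit leaves it open whether they differ.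

The compounds shown leave open whether the weaker numbers go with the cyclohexane ring or with the amide hydrogen that enters alongside it; an ethylamino group would keep that hydrogen without the ring, and a piperidine ring on the carbonyl carbon would keep a ring without that hydrogen. They also leave open how the series would respond if the fluorine on the phenyl ring gave way to a chlorine or a methoxy group.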